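The compounds below may be only part of what the source reports. "The series", "measured", "known", "first", "only" and "open" are said of these compounds alone.

In a functional assay on NCI-H460 cells (Homo sapiens) for cytotoxicity, read by MTT assay, with a stated time of 3 days (on this read-out lower numbers stand for stronger inhibition and higher numbers for weaker inhibition), three compounds on one shared core have been measured. Compound 1 `N#Cc1c(O)nc(SCc2nc3ccccc3[nH]2)nc1-c1ccccc1` gives 2.5 nM and compound 2 `N#Cc1c(NC(N)=S)nc(SCc2nc3ccccc3[nH]2)nc1-c1ccccc1` gives 3.37 nM, with a 1.3-fold higher number from compound 1 to compound 2 (0.13 log units; within the scatter). Compound 3 `N#Cc1c(NC(N)=O)nc(SCc2nc3ccccc3[nH]2)nc1-c1ccccc1` gives 14.7 nM, the highest of the three numbers, with a 5.9-fold higher number from compound 1 to compound 3 (0.77 log units; beyond the scatter) and a 4.4-fold higher number from compound 2 to compound 3 (0.64 log units; beyond the scatter). Compound 4 `N#Cc1c(-c2ccccc2)nc(SCc2nc3ccccc3[nH]2)nc1N1CCNCC1` follows from compound 3 by piperazin-1-yl in place of ureido on an aromatic carbon. Going by the values given here, no measured compound carries this ring, so the data offer only indirect guidance. Swaps at this carbon have so far moved the number modestly at most, and compound 3, at 14.7 nM, lies at the top of that span. A modest move towards a lower number in this assay is therefore expected, namely a 2.1-fold lower number from compound 3 to compound 4 (0.32 log units; beyond the scatter). For compound 4 the estimate is 7 nM, with an expected range from 2 nM to 30 nM.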

Compound 4, half-maximal inhibitory concentration: 7.35 nM
Compound 4: middle estimate off by 1.1-fold (0.02 log units), on the low side; the measured number falls inside the stated range.
By their numbers in this assay, from the lowest: compounds 1 and 2 (each within the scatter of the next); then compounds 4 and 3 (each within the scatter of the next).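

In this assay, a 2.0-fold lower number from compound 3 to compound 4 (0.30 log units; within the scatter) shows that a six-membered non-aromatic ring can replace the open ureido group at this aromatic carbon with no change beyond the scatter. Compared with the two lowest compounds, the ring gives a 2.2-fold higher number from compound 2 to compound 4 (0.34 log units; beyond the scatter) and a 2.9-fold higher number from compound 1 to compound 4 (0.47 log units; beyond the scatter), so these steps remain modest. No measurement shown accounts for these steps. On these data alone, whether 4-methylpiperazin-1-yl, morpholin-4-yl or an open-chain amine such as dimethylamino would keep the number in this span remains open.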